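This account rests on a few compounds, and the source may have more. Where it says the series, first, only, none or still open, it means among the compounds named here.

In an ADME assay on L02 cells (Homo sapiens) for cytotoxicity, read by MTT assay, with a stated time of 72 h (on this read-out higher numbers stand for weaker inhibition and lower numbers for stronger inhibition), compound 3 (`C=CC(=O)Nc1cccc(Oc2nc(Nc3ccc(OC)nc3)nc3c2CSCC3)c1`) gives > 50000 nM, which is a limit of the assay and not a number. Compound 1 (`CCC/C=C/C(=O)Nc1cccc(Oc2nc(Nc3cccc(C#N)c3)nc3c2CSCC3)c1`) gives > 50000 nM, also a limit. Compound 2 (`CCC/C=C/C(=O)Nc1cccc(Oc2nc(Nc3ccc(OC)cc3)nc3c2CSCC3)c1`) gives > 50000 nM, again a limit. Compound 4 (`CCC/C=C/C(=O)Nc1cccc(Oc2nc(Nc3ccc(OC)nc3)nc3c2CSCC3)c1`) carries pent-1-en-1-yl in place of vinyl on a carbonyl carbon. Within the data shown here, the one measured step, a step that the two limits leave unreadable from compound 1 to compound 2, is between two compounds that both carry pent-1-en-1-yl, and it offers no size to carry over. For compound 4, no step beyond the scatter is expected in this assay because the limit of > 50000 nM in this assay, at which 3 of the 3 values shown sit, is all that the measurements show. The expected change is a step that the limit leaves unreadable from compound 3 to compound 4, with no direction favoured. Compound 4 is estimated at 60000 nM, within an expected range from 30000 nM to 120000 nM.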

Compound 4, half-maximal inhibitory concentration: > 50000 nM
Compound 4 ended at the assay's limit; the forecaster's own chance of this, stated with the estimate: 90%; the middle value is on the limit's open side.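

No step can be read between compound 4 and compounds 1, 2 or 3, since all four sit at a limit of the assay and give no number. Left open is whether, in this assay, swapping vinyl for pent-1-en-1-yl or changing the group on the nitrogen makes any difference.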